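The source may report more compounds than this note shows. Statements on the series, on what has been measured and on what is new or still open speak of the compounds shown alone.

Compound 1 `CCCn1c(=O)c2nc(-c3cnn(Cc4cc(F)ccc4Cl)c3)[nH]c2n(CCC)c1=O`: in an in vitro assay on HEK293 cells for displacement of a labelled ligand from adenosine receptor A2b (Homo sapiens) (on this read-out lower numbers stand for stronger inhibition and higher numbers for weaker inhibition), compound 1 gives 4800 nM.
Compound 2 `CCCn1c(=O)c2nc(-c3cnn(Cc4cc(Cl)ccc4Cl)c3)[nH]c2n(CCC)c1=O`: in this assay compound 2 gives 29 nM.
Compound 3 `CCCn1c(=O)c2nc(-c3cnn(Cc4ccccc4OC)c3)[nH]c2n(CCC)c1=O`: in this assay compound 3 gives 37 nM.

All three share one core; they differ only in the benzyl group on a saturated chain carbon bound to an aromatic nitrogen. Compound 3 stands second highest of the three numbers, with compound 2 nearest at a 1.3-fold higher number from compound 2 to compound 3 (0.11 log units; within the scatter) and compound 1 furthest at a 130-fold lower number from compound 1 to compound 3 (2.11 log units; beyond the scatter).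

Compound 4 `CCCn1c(=O)c2nc(-c3cnn(Cc4cccc(F)c4F)c3)[nH]c2n(CCC)c1=O` has not yet been measured. Its change from compound 3 is 2,3-difluorophenyl in place of 2-methoxyphenyl on a saturated chain carbon bound to an aromatic nitrogen.

Among the measured compounds shown here, three steps bear on this. The step of a 130-fold lower number from compound 1 to compound 3 (2.11 log units; beyond the scatter) and the step of a 1.3-fold higher number from compound 2 to compound 3 (0.11 log units; within the scatter) show that the benzyl group can shift the number a great deal or hardly at all. The step of a 170-fold lower number from compound 1 to compound 2 (2.22 log units; beyond the scatter) shows that fluoro in place of chloro on this ring went with a much higher number. Since compound 4 carries two fluorines and no chlorine or methoxy, a higher number than compound 3 is expected, with wide uncertainty: the expected step is a 16-fold higher number from compound 3 to compound 4 (1.21 log units; beyond the scatter). Compound 4 is therefore estimated at 600 nM, with a range from 60 nM to 6000 nM.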

Compound 4, inhibition constant: 240 nM
The estimate for compound 4 lay 2.5-fold (0.40 log units) above the measured number; low and high end bracket the measured number.
By their numbers in this assay, from the lowest: compounds 2 and 3 (each within the scatter of the next); then compound 4; then compound 1.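

The step of a 20-fold lower number from compound 1 to compound 4 (1.30 log units; beyond the scatter) in this assay shows that carrying fluorine on the benzyl ring does not by itself give the very high number, since both of these rings carry it. Even so, the 2,3-difluorobenzyl group does not reach the low numbers, with a 6.5-fold higher number from compound 3 to compound 4 (0.81 log units; beyond the scatter) and an 8.3-fold higher number from compound 2 to compound 4 (0.92 log units; beyond the scatter), so this position now shows an intermediate level as well as the low and high numbers. No measurement shown here accounts for these differences between the benzyl groups.

Going by these compounds, it remains open how a plain unsubstituted benzyl, a ring with a single fluorine, or a benzyl carrying an amine or a carboxylic acid would read at this place. A longer chain between the ring and the aromatic nitrogen is equally untested among the compounds shown.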